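The source may hold more compounds than are shown below. What is called first, only, known or untested is meant among the compounds shown, and "the series" means these compounds.

Measured compounds, with the value in an assay on microsomes from liver for inhibition of sterol O-acyltransferase 1 (Rattus norvegicus); on this read-out higher numbers stand for weaker inhibition and lower numbers for stronger inhibition:

compound 1, `O=C(O)CCCCCCn1nc(-c2ccccc2)c(-c2ccccc2)cc1=O`: > 300000 nM; this is a limit of the assay, not a number.
compound 2, `O=C(O)CCCCCCCn1nc(-c2ccccc2)c(-c2ccccc2)cc1=O`: > 300000 nM; again a limit.
compound 3, `O=C(O)CCCCCCSc1cc(-c2ccccc2)c(-c2ccccc2)nn1`: > 300000 nM; also a limit.

Compound 1 and compound 2 share a core and differ by carboxymethyl in place of carboxy on a saturated chain carbon, six bonds along the chain from an aromatic nitrogen. The step that the two limits leave unreadable from compound 1 to compound 2 cannot be read, since both ends are limits; what the pair shows is only (the limit of > 300000 nM in this assay, at which 3 of the 3 values shown sit). Compound 3 carries a different core; the difference between the two cores is not broken down here.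

Compound 4, `O=C(O)CCCCCCCSc1cc(-c2ccccc2)c(-c2ccccc2)nn1`, is not yet measured in this assay. It differs from compound 3 by carboxymethyl in place of carboxy on a saturated chain carbon, six bonds along the chain from a sulfur. This is the same kind of change as from compound 1 to compound 2, but the place is not the same: six bonds along the chain from an aromatic nitrogen there, six bonds along the chain from a sulfur here.

In this assay the step is expected to be a step that the limit leaves unreadable from compound 3 to compound 4, an expectation resting on (the limit of > 300000 nM in this assay, at which 3 of the 3 values shown sit), where every value shown so far sits. Compound 4 is accordingly expected to give about 400000 nM, estimated between 100000 nM and 2000000 nM, and most likely reported as a limit only.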

Compound 4, half-maximal inhibitory concentration: > 300000 nM
Compound 4: a limit, no number (the forecaster's own chance of this, stated with the estimate: 85%); the middle value does not contradict the limit.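

No step can be read between compound 3 and compound 4, since in this assay both stand at a limit and not at a number: the limit of > 300000 nM in this assay, at which 4 of the 4 values shown sit.

The compounds shown leave open how large the change of carboxymethyl in place of carboxy is on either core, and what on these cores would bring a value inside the range of this assay.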